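A few compounds are considered here, and "the series" means these few. Any claim that something is new, unique, unknown or untested is made for them only; others in the source may bear on it.

Within the data shown here, compound 3 `O=C(/C=C/c1cc(C(=O)c2ccccc2)cn1Cc1ccccc1)CC(=O)C(=O)O` is the one member of this set for which a number rather than a limit stands: in an assay on isolated protein for inhibition of DNA nucleotidylexotransferase (Homo sapiens), read by scintillation counting, with a stated time of 10 min (a higher number here means a weaker inhibitor, a lower number a stronger inhibitor), compound 3 gives 16 uM. Compound 1 `CCOC(=O)C(=O)CC(=O)/C=C/c1cc(C(=O)c2ccccc2)cn1Cc1ccccc1` reaches only a limit in this assay, namely > 40 uM. Compound 2 `CCOC(=O)C(=O)CC(=O)/C=C/c1cc(C(=O)c2ccccc2)cn1Cc1ccc(C#N)cc1` likewise stops at a limit in this assay, with > 40 uM. Both of these sit at the limit of > 40 uM in this assay, at which 2 of the 3 values shown sit, so the step that the two limits leave unreadable from compound 1 to compound 2 cannot be read, while the step of an at least 2.5-fold lower number from compound 1 to compound 3 (0.39 log units; beyond the scatter) is at least modest.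

Compound 4 `N#Cc1ccc(Cn2cc(C(=O)c3ccccc3)cc2/C=C/C(=O)CC(=O)C(=O)O)cc1` carries the change (cyano in place of hydrogen on an aromatic carbon). This is the same change that separates compound 1 from compound 2, and the pair of limits there gives no direction and no size for it. The step from compound 1 to compound 3 concerns the ester and acid instead and does not speak to a cyano group. The expectation for compound 4 therefore rests on compound 3 alone, with no readable step to move it: the estimated step is no change at the digits printed from compound 3 to compound 4 (within the scatter), which amounts to none beyond the scatter. Compound 4 is thus expected to give about 16 uM in this assay, within a range from 6 uM to 45 uM.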

Compound 4, concentration for 50% inhibition: 6.8 uM
For compound 4 the middle estimate is 2.4-fold (0.37 log units) above the measured one; low and high end bracket the measured number.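

Among these compounds, with the acid in place, the change from benzyl to 4-cyanobenzyl can be read for the first time in this assay: it gives a 2.4-fold lower number from compound 3 to compound 4 (0.37 log units; beyond the scatter), so the cyano group para to a large group now has a direction and a size that the ester pair could not supply. Among the compounds shown here, the loss of the ethyl group, so far seen only on the unsubstituted benzyl core, can now also be followed on the 4-cyanobenzyl core, where it gives an at least 5.8-fold lower number from compound 2 to compound 4 (0.76 log units; beyond the scatter). The two ester-to-acid steps point the same way, but their sizes cannot be set against each other: the same change on two cores in this assay, an at least 2.5-fold lower number (0.39 log units; beyond the scatter) from compound 1 to compound 3 and an at least 5.8-fold lower number (0.76 log units; beyond the scatter) from compound 2 to compound 4; the limit leaves it open whether they differ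

The step between the two esters still cannot be read, and whether the cyano group has any bearing on the ester core remains unknown: the limit of > 40 uM in this assay, at which 2 of the 4 values shown sit. The compounds shown also leave open whether the lower number is particular to the cyano group or would also appear with another group at this place, such as an amine, a methoxy group or a chlorine atom.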